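Exchanging the Polar Head on Compound 2

A few compounds are considered here, and "the series" means these few. Any claim that something is new, unique, unknown or untested is made for them only; others in the source may bear on it.

Of the compounds shown here, three have been measured in a functional assay on NCI-H460 cells (Homo sapiens) for inhibition, read by MTT assay, with a stated time of 4 days; on this read-out higher numbers stand for weaker inhibition and lower numbers for stronger inhibition. Compound 1 `COc1ccc(C(=NNC(=O)NNC(=O)NCCCC(C)Nc2cc(OC)cc3cccnc23)c2ccc(OC)cc2)cc1` gives 5000 nM. Compound 2 `COc1cc(NC(C)CCCNC(=O)NNC(=O)N(CCO)CCO)c2ncccc2c1` returns only a limit, > 100000 nM, so no number is known for it. Compound 3 `O=C(NC(c1ccccc1)c1ccc(Cl)cc1)NC(c1ccccc1)c1ccc(Cl)cc1` likewise returns only a limit, > 100000 nM. Compound 2 thus stands at the limit of this assay, where most of the shown values sit: the limit of > 100000 nM in this assay, at which 2 of the 3 values shown sit. Compound 1 alone gives a value inside the measured range. No two of these compounds differ in a single place, so no measured step is available.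

Compound 4 `COc1cc(NC(C)CCCNC(=O)NNC(=O)NC(CO)(CO)CO)c2ncccc2c1` is the next compound for this assay. It differs from compound 2 in one place: (2-hydroxy-1,1-bis(hydroxymethyl)ethyl)amino in place of bis(2-hydroxyethyl)amino on a carbonyl carbon. The chain and the core of compound 2 are otherwise kept.

With compound 2 at a limit, the step to compound 4 cannot be set against any measured step. The change keeps the same carbonyl carbon and its amide-type nitrogen neighbour and alters only the hydroxylated group on it. Compound 4 is therefore expected to stay at or near the limit, and the expected step that the limit leaves unreadable from compound 2 to compound 4 is none beyond the scatter. Compound 4 is estimated at 150000 nM, in a range from 50000 nM to 500000 nM, with the most likely outcome again only a limit.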

Compound 4, half-maximal inhibitory concentration: > 100000 nM
Compound 4 was reported as a limit (the forecaster's own chance of this, stated with the estimate: 85%); the middle value does not contradict the limit.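

In this assay compound 4 returns only a limit, > 100000 nM. Compound 2 also returns only a limit, so no step can be read between compound 2 and compound 4, and both stand at the same place: the limit of > 100000 nM in this assay, at which 3 of the 4 values shown sit. The compounds shown leave open whether any other group on that carbonyl carbon would give a value inside the measured range.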